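An Extra Chain Double Bond on a Weak Antiproliferative Core

A few compounds are considered here, and "the series" means these few. Any claim that something is new, unique, unknown or untested is made for them only; others in the source may bear on it.

Measured so far:
compound 1, `CCCCC/C=C\C/C=C\CCCCCCCC1(O)CC(=O)c2c(O)cc(O)cc2O1`: 17500 nM
compound 2, `CCCCCCCCCCCCCCCc1cc(=O)c2c(O)c(C)c(O)c(C)c2o1`: > 67200 nM, a limit of the assay
compound 3, `CCCCC/C=C\C/C=C\CCCCCCCC1(O)CC(=O)c2c(O)cc(OCOC)cc2O1`: > 84100 nM, a limit of the assay

Going by the values given here, in a functional assay on MCF7 cells (Homo sapiens) for antiproliferative activity, read by MTT assay (on this read-out lower numbers stand for stronger inhibition and higher numbers for weaker inhibition), compound 1 is the only compound that gives a number at all. Compound 2 reaches only a limit, > 67200 nM, and so shows no number. Compound 3 likewise reaches only a limit, > 84100 nM. Among the compounds with values here, the single measured step, an at least 4.8-fold higher number from compound 1 to compound 3 (0.68 log units; beyond the scatter), concerns a change on an aromatic oxygen and tells nothing about the fatty chain.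

Compound 4, `CC/C=C\C/C=C\C/C=C\CCCCCCCC1(O)CC(=O)c2c(O)cc(O)cc2O1`, keeps the whole core and the chain length of compound 1 and differs from it only in the chain: but-1-en-1-yl in place of butyl on a saturated chain carbon bound to a double-bonded chain carbon. Within the data shown here, no measured step here touches a change of this kind, so there is nothing that would justify expecting a shift in either direction beyond the usual scatter. The step from compound 1 to compound 4 in this assay is therefore expected to be no change at the digits printed from compound 1 to compound 4 (within the scatter). Compound 4 is estimated at 17500 nM, with a range from 6000 nM to 50000 nM.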

Compound 4, half-maximal inhibitory concentration: 17500 nM
Compound 4: the middle estimate sits on the measured number at the digits printed, and the stated range covers the measured number.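

In this assay, putting but-1-en-1-yl in place of butyl on a saturated chain carbon bound to a double-bonded chain carbon gives no change at the digits printed from compound 1 to compound 4 (within the scatter), so the extra chain double bond leaves the reading where it was. Going by these compounds alone, the only earlier step, an at least 4.8-fold higher number from compound 1 to compound 3 (0.68 log units; beyond the scatter), concerned an aromatic oxygen, so this is the first step that reads the fatty chain itself, and unlike that step it stays within the scatter. Nothing shown here explains why this chain change leaves the number in place, since the available evidence concerns only the limits of the assay and does not bear on this step.

From the compounds shown here alone, the effect of other chain changes stays open: a longer chain, or a carboxylic acid or an amine placed on the chain, might behave differently from this added double bond. Compound 4 gives 17500 nM, and whether any change to the chain on the shared core can lower that number remains unanswered.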